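The source may hold more compounds than are shown below. What is called first, only, known or untested is meant among the compounds shown, and "the series" means these compounds.

In an ADME assay for pharmacokinetics (a higher number here means that the compound lasts longer, a lower number that the compound disappears faster), compound 1 (`CCCCC1=Nc2ccccc2S(=O)(=O)N1Cc1ccc(-c2ccccc2C(=O)O)cc1`) returns >> 24 h as its result, and this entry is a limit of the assay, not a number. Within the data shown here, compound 2 (`CCCCC1=NS(=O)(=O)c2ccccc2N1Cc1ccc(-c2ccccc2C(=O)O)cc1`) gives 0.667 h in this assay and so supplies the only actual number available, which makes it the sole measured reference point for what follows. The next compound, compound 3 (`CCCSC1=NS(=O)(=O)c2ccccc2N1Cc1ccc(-c2ccccc2C(=O)O)cc1`), keeps the core of compound 2 and alters one group: propylsulfanyl in place of butyl on a carbon with a double bond to nitrogen, between two ring nitrogen atoms (propylsulfanyl in place of butyl on a carbon with a double bond to nitrogen). Among the measured compounds shown here, no measured pair of compounds shows what such a change does, so there is no earlier step to lean on. The expectation therefore starts from compound 2 at 0.667 h and foresees no shift beyond the usual scatter in this assay in either direction. The estimated change is a 1.1-fold lower number from compound 2 to compound 3 (0.05 log units; within the scatter) and no more than that. For compound 3 the half-life is estimated at 0.6 h with an expected range from 0.2 h to 1.8 h across repeated measurements.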

Compound 3, half-life: 5 h
Compound 3: the middle estimate sits 8.3-fold (0.92 log units) below what was measured, outside the stated range (above it).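

Among these compounds, the step of a 7.5-fold higher number from compound 2 to compound 3 (0.87 log units; beyond the scatter) in this assay gives the first measured reading at this carbon with a double bond to nitrogen, between two ring nitrogen atoms, and it shows that the half-life responds to what sits there. The change is small in the terms counted: propylsulfanyl and butyl have the same number of heavy atoms, and the entering group differs by a sulfur in place of a carbon and by one hydrogen-bond acceptor. No measured property among the data bears on why this swap moves the half-life, so the result stands without an explanation.

Going by these compounds, it remains open whether the gain belongs to the sulfur or to the chain attached to it, a question that a propoxy group, a propylamino group or a longer sulfur-linked chain such as butylsulfanyl at this carbon would address. Compound 1 gives >> 24 h, which is a limit of the assay and not a number, so how far the half-life can extend within this family also stays unsettled.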